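The compounds below may be only part of what the source reports. "The series", "measured", "known", "first", "only" and "open" are said of these compounds alone.

Compound 1 `O=C(c1cn[nH]c1)N1CCC(C(=O)N2N=CCC2c2ccccc2)CC1` — a physicochemical assay for lipophilicity, read by HPLC, measured as chromatographic lipophilicity, at pH 7.4; a higher number here means a more lipophilic compound, a lower number a more polar compound: 2.1
Compound 2 `O=C(c1ccccn1)N1CCC(C(=O)N2N=CCC2c2ccccc2)CC1` — this assay: 3.1
Compound 3 `O=C(c1cc[nH]n1)N1CCC(C(=O)N2N=CCC2c2ccccc2)CC1` — this assay: 2.4

Compound 3 stands second highest of the three numbers in this assay; its nearest neighbour is compound 1, with a number 0.30 log units higher from compound 1 to compound 3 (within the scatter), and its furthest is compound 2, with a number 0.70 log units lower from compound 2 to compound 3 (beyond the scatter). Compound 4 `O=C(c1cocn1)N1CCC(C(=O)N2N=CCC2c2ccccc2)CC1` differs from compound 3 in one place: 1,3-oxazol-4-yl in place of 1H-pyrazol-3-yl on a carbonyl carbon. For the measured compounds named here, no measured step swaps a 1H-pyrazol-3-yl for a 1,3-oxazol-4-yl, so the bearing is indirect. The measured steps of a number 1.00 log units higher from compound 1 to compound 2 (beyond the scatter) and a number 0.70 log units lower from compound 2 to compound 3 (beyond the scatter) place the pyridin-2-yl compound modestly above both pyrazolyl compounds, while a number 0.30 log units higher from compound 1 to compound 3 (within the scatter) lies within the scatter. For compound 4 the expected step is a number 0.20 log units higher from compound 3 to compound 4 (within the scatter), within the scatter, upward if anything. Compound 4 is estimated at 2.6, with a range of 2.1 to 3.1.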

Compound 4, distribution coefficient: 2.9
Beside the measured number, compound 4's estimate is 0.30 log units below it; low and high end bracket the measured number.
By their numbers in this assay, from the lowest: compounds 1 and 3 (each within the scatter of the next); then compounds 4 and 2 (each within the scatter of the next).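

In this assay, a five-membered aromatic ring with 2 hetero atoms on this carbonyl carbon need not sit with the pyrazolyl compounds: 1,3-oxazol-4-yl clears both (a number 0.50 log units higher from compound 3 to compound 4 (beyond the scatter); a number 0.80 log units higher from compound 1 to compound 4 (beyond the scatter)). It also stays within the scatter of the six-membered pyridin-2-yl group (a number 0.20 log units lower from compound 2 to compound 4 (within the scatter)), so ring size alone does not sort these four compounds. No available measurement explains these steps. Still open, on these data alone, is where an amine or a carboxylic acid on this carbonyl carbon would fall. Also open, as far as these compounds go, is whether the 1,3-oxazol-4-yl step carries over to another core.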